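The compounds below may be only part of what the source reports. "The series", "measured", "known", "first", "only" and "open" are said of these compounds alone.

Compound 1 `COc1ccc(-c2cc(=O)c3cc(NC(C)=O)ccc3o2)cc1` was examined in an ADME assay on THP-1 cells (Homo sapiens) for cytotoxicity, read by flow cytometry and propidium iodide staining, with a stated time of 72 h (a lower number here means a stronger inhibitor, a higher number a weaker inhibitor), where compound 1 gives 74000 nM. Compound 2 `CC(=O)Nc1ccc2oc(-c3ccc(F)cc3)cc(=O)c2c1`, in this assay, gives 22000 nM. The step between them, a 3.4-fold lower number from compound 1 to compound 2 (0.53 log units; beyond the scatter), goes with fluoro in place of methoxy on an aromatic carbon.

Compound 3 `COc1cccc(-c2cc(=O)c3cc(N)ccc3o2)c1` stands apart from the pair. In this assay compound 3 reaches only the limit of the measurement, > 125000 nM, as noted in the limit of > 125000 nM in this assay, at which 1 of the 3 values shown sits. How the core of compound 3 differs from the core of compound 1 is not broken down here.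

Compound 4 `Nc1ccc2oc(-c3cccc(F)c3)cc(=O)c2c1` has not yet been measured. From compound 3 to compound 4 the change is fluoro in place of methoxy on an aromatic carbon. It is the same kind of change as from compound 1 to compound 2, but the place differs: para to a large group in the first pair, meta to a large group in the second.

The step expected from compound 3 to compound 4 in this assay is an at least 2.0-fold lower number from compound 3 to compound 4 (0.31 log units; beyond the scatter), set beside the measured 3.4-fold lower number from compound 1 to compound 2 (0.53 log units; beyond the scatter) and resting on that one pair alone, while compound 3 itself gave only a limit. Compound 4 is therefore estimated at 60000 nM, between 20000 nM and 200000 nM.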

Compound 4, half-maximal inhibitory concentration: > 125000 nM
Compound 4 ended at the assay's limit; the forecaster's own chance of this, stated with the estimate: 40%; at least 2.0-fold (0.31 log units) between middle value and limit.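

Compound 3 and compound 4 both sit at the assay's limit in this assay, so no step between them can be read: the limit of > 125000 nM in this assay, at which 2 of the 4 values shown sit.

The compounds shown leave open whether fluoro in place of methoxy, meta to a large group, changes the number at all, as neither compound gives a value inside the measurable range.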